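Compound 4: 4-methylbenzyl on the amide-type nitrogen

The source may report more compounds than this note shows. Statements on the series, on what has been measured and on what is new or still open speak of the compounds shown alone.

In a functional assay on HeLa cells (Homo sapiens) for inhibition, read by MTT assay, with a stated time of 48 h (on this read-out higher numbers stand for weaker inhibition and lower numbers for stronger inhibition), compound 3 `COc1ccc(NC(=O)/C=C/c2coc3cc(OC)ccc3c2=O)cc1` gives 13000 nM and compound 2 `COc1ccc2c(=O)c(/C=C/C(=O)NCc3cccc(F)c3)coc2c1` gives 17600 nM; these two values lie within the scatter of each other. Compound 1 `COc1ccc2c(=O)c(/C=C/C(=O)Nc3ccccc3)coc2c1` reads > 100000 nM, which is a limit of the assay and not a number.

Compound 4 `COc1ccc2c(=O)c(/C=C/C(=O)NCc3ccc(C)cc3)coc2c1` keeps the shared core and carries 4-methylbenzyl in place of 4-methoxyphenyl on an amide-type nitrogen.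

The closest measured step is a 1.4-fold lower number from compound 2 to compound 3 (0.13 log units; within the scatter), which exchanges 3-fluorobenzyl for 4-methoxyphenyl at the same nitrogen and stays within the scatter. The two steps away from the limit are larger, an at least 5.6-fold lower number from compound 1 to compound 2 (0.75 log units; beyond the scatter) and an at least 7.6-fold lower number from compound 1 to compound 3 (0.88 log units; beyond the scatter), but both give only a bound on size. They show that the group on this nitrogen can matter, so the range is kept wide, especially towards higher numbers. Neither 4-methylbenzyl nor any other methyl-bearing group has been measured in this series.

The expected step is small, a 1.2-fold higher number from compound 3 to compound 4 (0.09 log units; within the scatter), and is estimated to lie within the scatter in this assay. For compound 4 the estimated value is 16000 nM, with an expected range of 6000 nM to 45000 nM.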

Compound 4, half-maximal inhibitory concentration: > 100000 nM
Compound 4: no number, only a limit (the forecaster's own chance of this, stated with the estimate: 10%); middle value at least 6.2-fold (0.79 log units) away from the limit.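

In this assay, within the data shown here, the group on the amide-type nitrogen now shows a large step in a direction the earlier compounds did not: 4-methylbenzyl in place of 4-methoxyphenyl gives an at least 7.6-fold higher number from compound 3 to compound 4 (0.88 log units; beyond the scatter). Within the benzyl-type amides, the substituent on the aromatic ring also matters, as 4-methylphenyl in place of 3-fluorophenyl on the saturated chain carbon gives an at least 5.6-fold higher number from compound 2 to compound 4 (0.75 log units; beyond the scatter), so a benzyl-type group on this nitrogen does not by itself keep the number as low as in compound 2. The step from compound 1 to compound 4 cannot be read because both compounds sit at a limit, which is not a number: the limit of > 100000 nM in this assay, at which 2 of the 4 values shown sit.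

The step from compound 3 to compound 4 changes both the link to the ring and the ring substituent, so a 4-methoxybenzyl group on the same nitrogen would be needed to separate the two changes. Also open, from the compounds shown here alone, is how the series reads with an amine or a carboxylic acid on the aromatic ring, or with a longer chain on the amide-type nitrogen.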